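The compounds below may be only part of what the source reports. "The series", "measured", "known", "first", "only" and "open" are said of these compounds alone.

Compound 1, `CC(=O)N1CC=C(c2ccn3c(-c4ccc(NC(=O)c5ccc([N+](=O)[O-])o5)cc4)cnc3c2)CC1`, is followed here in a functional assay on AGS cells (Homo sapiens) for antiproliferative activity, read by CCK-8 assay, with a stated time of 72 h (on this read-out higher numbers stand for weaker inhibition and lower numbers for stronger inhibition), where compound 1 gives 410 nM. Among the three compounds measured it stands at the lowest number: compound 2, `O=C(Nc1ccc(-c2cnc3cc(C4=CCN(C5COC5)CC4)ccn23)cc1)c1ccc([N+](=O)[O-])o1`, gives 790 nM, and compound 3, `CN1CCCN(c2ccn3c(-c4ccc(NC(=O)c5ccc([N+](=O)[O-])o5)cc4)cnc3c2)CC1`, gives 2700 nM. The step of a 1.9-fold higher number from compound 1 to compound 2 (0.28 log units; within the scatter) lies within the scatter, while the step of a 6.6-fold higher number from compound 1 to compound 3 (0.82 log units; beyond the scatter) is modest and beyond it.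

Compound 4, `O=C(Nc1ccc(-c2cnc3cc(Cl)ccn23)cc1)c1ccc([N+](=O)[O-])o1`, differs from compound 1 as follows: one chlorine atom in place of a group of 9 heavy atoms (7 carbon, 1 nitrogen, 1 oxygen; one six-membered non-aromatic ring with 1 hetero atom), on an aromatic carbon. Going by the values given here, of the measured steps, only the one from compound 1 to compound 3 bears on it, since it too alters the group on that aromatic carbon, and it weakened inhibition modestly. Among the compounds with values here, no measured step removes the whole ring-bearing group in favour of a single atom, so the present change goes further than anything measured. The step of a 9.8-fold higher number from compound 1 to compound 4 (0.99 log units; beyond the scatter) is therefore expected to weaken inhibition, plausibly by more than the step to compound 3. Compound 4 is estimated at 4000 nM, with a range of 1000 nM to 16000 nM.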

Compound 4, half-maximal inhibitory concentration: 1700 nM
Beside the measured number, compound 4's estimate is 2.4-fold (0.37 log units) above it, within the range that was stated.
By their numbers in this assay, from the lowest: compounds 1 and 2 (each within the scatter of the next); then compounds 4 and 3 (each within the scatter of the next).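

In this assay, the whole ring-bearing group on this aromatic carbon can give way to a single chlorine atom at a modest cost: a 4.1-fold higher number from compound 1 to compound 4 (0.62 log units; beyond the scatter), and likewise a 2.2-fold higher number from compound 2 to compound 4 (0.33 log units; beyond the scatter). The seven-membered ring of compound 3 does not separate from chloro, with a 1.6-fold lower number from compound 3 to compound 4 (0.20 log units; within the scatter), so at this position 4-methyl-1,4-diazepan-1-yl offers no measurable gain over a lone chlorine, whereas the groups of compound 1 and compound 2 do. Nothing available accounts for these differences. On these data alone, it remains open whether a morpholine or an open-chain amine on this carbon would fall nearer compound 1 or compound 4. As far as these compounds go, it also remains open whether a methyl or methoxy group would match chloro.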